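A few compounds are considered here, and "the series" means these few. Any claim that something is new, unique, unknown or untested is made for them only; others in the source may bear on it.

Measured so far:

Compound 1 `CC#CCn1c(N2CCC[C@@H](N)C2)cc(=O)n(Cc2cc(C(=O)OC)ccc2Br)c1=O`: in an assay on isolated protein for inhibition of Dipeptidyl peptidase 9 (Homo sapiens), read by fluorescence, with stated times of 15 min and 20 min (a lower number here means a stronger inhibitor, a higher number a weaker inhibitor), compound 1 gives > 100 nM, which is a limit of the assay and not a number.
Compound 2 `CC#CCn1c(N2CCC[C@@H](N)C2)cc(=O)n(Cc2cccc(C(=O)OC)c2Br)c1=O`: in this assay compound 2 gives > 100 nM, again a limit.
Compound 3 `CC#CCn1c(N2CCC[C@@H](N)C2)cc(=O)n(Cc2cc(C(=O)OC)ccc2F)c1=O`: in this assay compound 3 gives > 100 nM, again a limit.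

The three measured compounds share most of their structure. Compound 1 and compound 2 are built from the same atoms joined differently, and the difference between the two cores is not broken down here. From compound 1 to compound 3 the change is fluoro in place of bromo on an aromatic carbon, and the step it made is a step that the two limits leave unreadable from compound 1 to compound 3; the size cannot be read because of the limit of > 100 nM in this assay, at which 3 of the 3 values shown sit.

The unmeasured compound 4 `CC#CCn1c(N2CCC[C@@H](N)C2)cc(=O)n(Cc2cccc(C(=O)OC)c2F)c1=O` differs from compound 2 by fluoro in place of bromo on an aromatic carbon. This is the same kind of change as from compound 1 to compound 3, not the same change: in compound 3 the fluoro sits para to a methoxycarbonyl group, in compound 4 it sits ortho to a methoxycarbonyl group.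

Compound 2 stands at a limit, > 100 nM. In this assay the expected step is a step that the limit leaves unreadable from compound 2 to compound 4, and this expectation rests on the earlier step that the two limits leave unreadable from compound 1 to compound 3 being unreadable and on (the limit of > 100 nM in this assay, at which 3 of the 3 values shown sit), which leaves no sign that this change brings a compound below the limit. For compound 4 the estimate in this assay is 400 nM, spanning 100 nM to 5000 nM, and the most likely outcome is expected to be once more only a limit.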

Compound 4, half-maximal inhibitory concentration: > 100 nM
Compound 4 ended at the assay's limit; the forecaster's own chance of this, stated with the estimate: 80%; the middle value is on the limit's open side.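

In this assay compound 4 gives > 100 nM, which is a limit of the assay and not a number. No size can be read for the change from compound 2 to compound 4, because neither compound has a value beyond the limit: the limit of > 100 nM in this assay, at which 4 of the 4 values shown sit.

The compounds shown leave open how strongly any of the four inhibits the protein, and whether fluoro in place of bromo changes that at all.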